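Chain-terminus variation on the isoflavone-type ether series

This account rests on a few compounds, and the source may have more. Where it says the series, first, only, none or still open, it means among the compounds named here.

Three compounds of the shared core, differing only in the ether chain on the aromatic oxygen, have been run in a functional assay on mitochondria (Cricetulus griseus) for inhibition of Monoamine oxidase (Homo sapiens), tested at 0.9 uM; a higher number here means a stronger effect of the compound at the concentration tested, a lower number a weaker effect. Compound 1 `O=c1c(-c2ccc(O)cc2)coc2cc(OCCCCCCBr)ccc12` gives 71.2%. Compound 2 `O=c1c(-c2ccc(O)cc2)coc2cc(OCCCCBr)ccc12` gives 55.3%. Compound 3 `C=CCOc1ccc2c(=O)c(-c3ccc(O)cc3)coc2c1` gives 68.8%. Compound 2 stands lowest of the three: the step of a number 13.5 percentage points higher from compound 2 to compound 3 (beyond the scatter) and the step of a number 15.9 percentage points lower from compound 1 to compound 2 (beyond the scatter) both lie beyond the scatter, while the step of a number 2.4 percentage points lower from compound 1 to compound 3 (within the scatter) lies within it.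

The next compound, compound 4 `O=C(O)CCCCCCOc1ccc2c(=O)c(-c3ccc(O)cc3)coc2c1`, is reached from compound 2 by the change (2-carboxyethyl in place of bromo on a saturated chain carbon, four bonds along the chain from an oxygen on an aromatic ring). Within the data shown here, only one measured step bears on it, the step of a number 15.9 percentage points lower from compound 1 to compound 2 (beyond the scatter), which shows that a longer chain from the aromatic oxygen gave a modestly higher read-out; no measured compound carries a carboxylic acid, so that part of the change has no precedent here. The longer chain alone suggests a modest rise of a number 7.7 percentage points higher from compound 2 to compound 4 (within the scatter) is expected in this assay. Compound 4 is therefore estimated at 63%, with a range from 45% to 80%.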

Compound 4, a percentage reported as inhibition, at one concentration (the size of the read-out at that concentration, not a potency): 71.2%
Estimate against measurement, compound 4: 8.2 percentage points below, within the range that was stated.
By their numbers in this assay, from the lowest: compound 2; then compounds 3, 1 and 4 (each within the scatter of the next).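

The carboxy terminus carries no penalty in this assay: with the chain held as in compound 1, carboxy in place of bromo gives no change at the digits printed from compound 1 to compound 4 (within the scatter). 5-Carboxypentyl in place of vinyl gives a number 2.4 percentage points higher from compound 3 to compound 4 (within the scatter), while 2-carboxyethyl in place of bromo gives a number 15.9 percentage points higher from compound 2 to compound 4 (beyond the scatter), so compounds 1, 3 and 4 form one group and compound 2 alone stands apart. No measurement at hand accounts for these read-outs.

A carboxylic acid on the shorter chain of compound 2 would separate the effect of chain length from that of the terminal group, which the step from compound 2 to compound 4 changes together. From the compounds shown here alone, how an amine, an ester or an amide at the chain end, or a longer chain, would read also stays open, as does whether a single concentration hides potency differences among compounds 1, 3 and 4.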